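Halogen on the Benzylidene Ring: From Compound 3 to Compound 4

This account rests on a few compounds, and the source may have more. Where it says the series, first, only, none or still open, it means among the compounds named here.

Measured in a functional assay on PC-3 cells (Homo sapiens) for antiproliferative activity, read by MTT assay, with a stated time of 72 h; a higher number here means a weaker inhibitor, a lower number a stronger inhibitor:
- compound 1 `O=C(N/N=C/c1ccccc1)Nc1ccc(Oc2ccnc3[nH]ccc23)c(F)c1` gives 7940 nM
- compound 2 `O=C(N/N=C/c1cccc(Br)c1)Nc1ccc(Oc2ccnc3[nH]ccc23)c(F)c1` gives 4020 nM
- compound 3 `N#Cc1ccc(/C=N/NC(=O)Nc2ccc(Oc3ccnc4[nH]ccc34)c(F)c2)cc1` gives 9030 nM

Compound 3, at 9030 nM, cannot be told apart from compound 1, as the set shows a 1.1-fold higher number from compound 1 to compound 3 (0.06 log units; within the scatter). It does separate from compound 2, with a 2.2-fold higher number from compound 2 to compound 3 (0.35 log units; beyond the scatter), though only modestly.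

Compound 4 `O=C(N/N=C/c1cccc(Cl)c1Cl)Nc1ccc(Oc2ccnc3[nH]ccc23)c(F)c1` has not yet been measured. Its change is 2,3-dichlorophenyl in place of 4-cyanophenyl on a carbon with a double bond to nitrogen.

Among the compounds with values here, no measured compound carries this group. Within the data shown here, the nearest guide is compound 2, the only halogen-bearing member, which shows a 2.0-fold lower number from compound 1 to compound 2 (0.30 log units; within the scatter). Compound 3 shows no clear shift from compound 1, so the comparison with compound 2 suggests a small move towards a lower number in this assay. The expected step is a 1.9-fold lower number from compound 3 to compound 4 (0.27 log units; within the scatter). The estimate for compound 4 is 4800 nM, with an expected range of 1900 nM to 11000 nM.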

Compound 4, half-maximal inhibitory concentration: "not active" (no number reported)
For compound 4 the study gives words and no number; the estimate stays without a comparison.
By their numbers in this assay, from the lowest: compounds 2, 1 and 3 (each within the scatter of the next, the first and the last beyond it).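

In this assay, within the data shown here, compound 4 is reported only in words, as not active, and without a number no step from compound 3 or any other compound can be read. The compounds shown leave open how far compound 4 lies from compounds 1, 2 and 3, and nothing available here explains its result.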